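Swapping the Chlorophenyl of Compound 2 for a Thiazole

This account rests on a few compounds, and the source may have more. Where it says the series, first, only, none or still open, it means among the compounds named here.

For the measured compounds named here, the first compound of this series is compound 1 `COc1ncc(-c2ccccc2)cc1[C@@H](c1ccccc1)[C@@](O)(CCN(C)C)c1ccccc1`. In a toxicity assay on HeLa cells (Homo sapiens) for cytotoxicity (a lower number here means that less compound is tolerated, a higher number that more compound is tolerated), compound 1 gives 11.9 ug/mL. Compound 2 `COc1nc(-c2ccc(Cl)cc2)ccc1[C@@H](c1ccccc1)[C@@](O)(CCN(C)C)c1cccc2ccccc12` differs from compound 1 in several places at once, so no single change links the two. In this assay compound 2 reaches only a limit, > 64 ug/mL, and not a number. Going by the values given here, the one piece of evidence on where compound 2 stands is the limit of > 64 ug/mL in this assay, at which 1 of the 2 values shown sits.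

Compound 3 `COc1nc(-c2cnsc2)ccc1[C@@H](c1ccccc1)[C@@](O)(CCN(C)C)c1cccc2ccccc12` has not yet been measured. It differs from compound 2 in one place only: 1,2-thiazol-4-yl in place of 4-chlorophenyl on an aromatic carbon. Among the compounds with values here, because no step between measured compounds is available, the size of this change can only be guessed. The expected step from compound 2 to compound 3 is a number no higher from compound 2 to compound 3 (the limit leaves the size open), that is, nothing clearly beyond the usual scatter. Compound 3 is therefore expected to give about 64 ug/mL in this assay, within a range from 30 ug/mL to 130 ug/mL, with a fair chance that again only a limit is reported.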

Compound 3, half-maximal cytotoxic concentration: 28.8 ug/mL
Compound 3: middle estimate off by 2.2-fold (0.35 log units), on the high side; the measured number lies below the stated range.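

For the compounds shown here, this is the first change that can be read at a single place: on the aromatic carbon next to the ring nitrogen, 1,2-thiazol-4-yl in place of 4-chlorophenyl gives an at least 2.2-fold lower number from compound 2 to compound 3 (0.34 log units; beyond the scatter). In this assay a lower number means that less compound is tolerated, so the group at this position matters, and less of the compound carrying 1,2-thiazol-4-yl is tolerated than of the one carrying 4-chlorophenyl. The full size of this step stays open, because compound 2 reaches only a limit and not a number: the limit of > 64 ug/mL in this assay, at which 1 of the 3 values shown sits.

This single swap cannot tell whether the shift goes with the loss of the chlorine, the change from a six-membered to a five-membered ring, or the hetero atoms that enter with the new ring. As far as these compounds go, whether the trend holds for other groups at this position, such as a pyridin-3-yl ring or an amine like morpholine, remains open, as does whether the same swap would have a similar effect on the core of compound 1.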